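Benzyl for Methyl on Selenium Among Compounds at the Limit

This account rests on a few compounds, and the source may have more. Where it says the series, first, only, none or still open, it means among the compounds named here.

The measured compounds in a functional assay on HT-29 cells (Homo sapiens) for cytotoxicity, read by MTT assay, with a stated time of 72 h; on this read-out higher numbers stand for weaker inhibition of growth and lower numbers for stronger inhibition of growth:
Compound 1 `C[Se]/C(=N\C(=O)c1sccc1Cl)NC(=O)c1sccc1Cl` gives > 100000 nM, a limit of the assay and not a number.
Compound 2 `C[Se]/C(=N\C(=O)c1cnc2ccccc2c1)NC(=O)c1cnc2ccccc2c1` gives > 100000 nM, again a limit of the assay.
Compound 3 `O=C(/N=C(/NC(=O)c1csc([N+](=O)[O-])c1)[Se]Cc1ccccc1)c1csc([N+](=O)[O-])c1` gives > 100000 nM, also a limit of the assay.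

Compound 2 therefore stands nowhere in particular within the measured set: its value in this assay is a limit, and every other value shown is the same limit, as the limit of > 100000 nM in this assay, at which 3 of the 3 values shown sit, makes plain. Among the compounds with values here, no two of the measured compounds differ in a single place, so no step between measured compounds can be drawn, and no compound can be called stronger or weaker than another.

Compound 4 `O=C(/N=C(/NC(=O)c1cnc2ccccc2c1)[Se]Cc1ccccc1)c1cnc2ccccc2c1` has not yet been measured. It differs from compound 2 by phenyl in place of hydrogen on a saturated chain carbon bound to a selenium atom. Compound 3 carries the same benzyl on selenium and sits at the limit of this assay, as its value of > 100000 nM shows.

With every measured value a limit, there is no ground for expecting a step beyond the scatter in either direction. Compound 4 is estimated at 150000 nM, expected to lie between 50000 nM and 500000 nM. The expected step is a step that the limit leaves unreadable from compound 2 to compound 4, that is, none beyond the scatter, with the assay most likely again reporting only a limit.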

Compound 4, concentration for total growth inhibition: > 100000 nM
Compound 4 ended at the assay's limit; the forecaster's own chance of this, stated with the estimate: 85%; the middle value lies beyond the limit too.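

In this assay compound 4 gives > 100000 nM, a limit of the assay and not a number. Within the data shown here, compound 2 sits at the same limit, so no step for the change from methyl to benzyl can be read between compound 2 and compound 4. The compounds shown leave open whether any change to these structures brings growth inhibition into a range this assay can read: the limit of > 100000 nM in this assay, at which 4 of the 4 values shown sit.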